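The source may hold more compounds than are shown below. What is called first, only, known or untested is meant among the compounds shown, and "the series" means these compounds.

The account begins with compound 1 `Cn1cc(-c2n[nH]c3ccc(NC4CCNC4)cc23)cn1`, a compound for which no potency number exists: in an assay on HEK293 cells for displacement of a labelled ligand from tyrosine-protein kinase receptor UFO (Homo sapiens), read by NanoBRET, with a stated time of 2 h (a lower number here means a stronger inhibitor, a higher number a weaker inhibitor), compound 1 is recorded as "not determined" (no result reported), so it stands nowhere on the scale that the rest of this set uses. For the measured compounds named here, the only measured point on that scale is compound 2 `N#Cc1ccc(-n2cc(-c3n[nH]c4cc(Cl)c(N[C@@H]5CCNC5)cc34)cn2)cc1`, which in this assay gives 880 nM; compound 2 carries a chloro group and a nitrile-bearing phenyl ring that compound 1 lacks, and no step between it and compound 1 has been computed, so its value shows only the general range in which a member of this series has been found to sit.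

The move from compound 1 to compound 3 `Cn1cc(-c2n[nH]c3ccc(N[C@@H]4CCNC4)cc23)cn1` is the smallest one a chemist can make: the two compounds have the same atoms and bonds; at least one stereo element is drawn with a configuration in one of them and without one in the other: 1 of 1 stereo elements differ; a stereocentre at a saturated ring carbon is drawn without a configuration in compound 1 and R in compound 3. Compound 3 is thus a single drawn configuration of what compound 1 leaves open. Compound 1 has no number in this assay. No step size can be stated, and none is expected to be visible beyond the usual scatter. For compound 3 the potency in this assay is estimated at 1500 nM, within a range from 300 nM to 8000 nM.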

Compound 3, half-maximal inhibitory concentration: 20700 nM
Compound 3: middle estimate off by 14-fold (1.14 log units), on the low side; measured number outside the range, above it.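

For the compounds shown here, compound 1 has no number in this assay, so no step from it to compound 3 can be read, and the value of compound 3, 20700 nM, stands without a partner. The compounds shown leave open whether the configuration matters for potency at all, the only known difference between them being this: the fact that one of compounds 1 and 3 is drawn with a defined configuration and the other without, at the place where they differ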